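A few compounds are considered here, and "the series" means these few. Any claim that something is new, unique, unknown or untested is made for them only; others in the source may bear on it.

Working notes on the series. Compound 1 `Cc1ccc2c(O)cc(-c3cccc(Cl)c3)nc2n1` gives 41.7 nM in a functional assay on CAKI-1 cells (Homo sapiens) for antiproliferative activity; a lower number here means a stronger inhibitor of growth, a higher number a weaker inhibitor of growth. Compound 2 `Cc1cccc(-c2cc(O)c3c(C)cc(C)nc3n2)c1` gives 56200 nM. Compound 3 `Cc1cc(C)c2c(O)cc(-c3cccc(Cl)c3)nc2n1` gives 204 nM, the second highest of the three numbers; the steps of a 4.9-fold higher number from compound 1 to compound 3 (0.69 log units; beyond the scatter) and a 280-fold lower number from compound 2 to compound 3 (2.44 log units; beyond the scatter) set it between the other two. Compound 4 `Cc1cc(C)c2c(O)cc(-c3cccc(F)c3)nc2n1` differs from compound 3 by fluoro in place of chloro on an aromatic carbon. Going by the values given here, only one measured step touches the same aromatic carbon, and it was large: a 280-fold lower number from compound 2 to compound 3 (2.44 log units; beyond the scatter). That step shows the number depends strongly on what stands at this place, so a higher number than for chloro is expected, though well short of the number seen with methyl. The expected step is a 7.4-fold higher number from compound 3 to compound 4 (0.87 log units; beyond the scatter). Compound 4 is therefore estimated at 1500 nM, with a range from 400 nM to 6000 nM.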

Compound 4, concentration for 50% growth inhibition: 35.5 nM
The estimate for compound 4 lay 42-fold (1.63 log units) above the measured number, and the stated range ends above it.
By their numbers in this assay, from the lowest: compounds 4 and 1 (each within the scatter of the next); then compound 3; then compound 2.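

At this aromatic carbon in this assay chloro is not the best of the groups seen, since the change to fluoro gives a 5.7-fold lower number from compound 3 to compound 4 (0.76 log units; beyond the scatter) and the change from methyl gives a 1600-fold lower number from compound 2 to compound 4 (3.20 log units; beyond the scatter) and so extends the gain already seen with chloro. The number thus falls from methyl through chloro to fluoro across these three compounds. Nothing at hand gives a reason for this order.

Open, as far as these compounds go, is whether an amine, a methoxy group or a carboxylic acid at this place would keep the number this low. Also open, from the compounds shown here alone, is whether fluoro brings the same change on the core of compound 1 .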